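A methyl fewer on the chain of compound 2

The source may hold more compounds than are shown below. What is called first, only, known or untested is meant among the compounds shown, and "the series" means these compounds.

Compound 2 (`CCCC(=O)n1c(=S)[nH]c2ccccc21`) stands at 190000 nM in a physicochemical assay for solubility (a higher number here means a more soluble compound, a lower number a less soluble compound), and serves as the starting point here. Compound 3 (`CCCCCC(=O)n1c(=O)oc2ccccc21`) gives 150000 nM in the same measurement, which is within the scatter of compound 2. Compound 1 (`CCCCCCCCCCCCCCCC(=O)n1c(=S)oc2ccccc21`) reads 63000 nM on this scale, a lower number than compound 2 and beyond the scatter.

Compound 4 (`CCC(=O)n1c(=S)[nH]c2ccccc21`) has not yet been measured. It departs from compound 2 by a single change, hydrogen in place of methyl on a saturated chain carbon, two bonds along the chain from a carbonyl carbon, so that propylcarbonyl becomes propanoyl.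

Going by the values given here, no two measured compounds differ in one place only, so the data give no direct measure of such a change. The expectation therefore rests on the value of compound 2 at 190000 nM and on how small the change is. The expected step of a 1.1-fold higher number from compound 2 to compound 4 (0.04 log units; within the scatter) in this assay is estimated to be a slight move to a higher number, within the scatter.

For compound 4 the estimate is 210000 nM as the expected value, with an expected range from 120000 nM to 350000 nM in this measurement.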

Compound 4, solubility: 180000 nM
Beside the measured number, compound 4's estimate is 1.2-fold (0.07 log units) above it, and the stated range covers the measured number.
By their numbers in this assay, from the lowest: compound 1; then compounds 3, 4 and 2 (each within the scatter of the next).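

Going from propylcarbonyl to propanoyl gives a 1.1-fold lower number from compound 2 to compound 4 (0.02 log units; within the scatter) in this assay, so at this position, on a saturated chain carbon, two bonds along the chain from a carbonyl carbon, hydrogen in place of methyl does not separate the two compounds on this scale. Going by these compounds alone, this pair is the first in the set to differ in one place only, which makes it the first direct reading of a single change, though it speaks for this one change on this one core. Nothing at hand bears on why the step has this size.

As far as these compounds go, it remains open whether a longer chain on the core of compound 2 would read the same, since compound 1 and compound 3 differ from compound 2 in more than one place and so cannot answer that. Also open, from the compounds shown here alone, is what a hydroxyl, an amine or a carboxylic acid at this carbon would do, and whether the same swap of hydrogen for methyl would give a similar step on the core of compound 3.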